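This account rests on a few compounds, and the source may have more. Where it says the series, first, only, none or still open, it means among the compounds named here.

The measured compounds:

compound 1, `Cc1cc(O)c(C(C)C)cc1-c1cc(-c2ccccc2[N+](=O)[O-])c(C#N)c(=O)[nH]1`, which in a functional assay for inhibition, tested at 40 ug/mL (on this read-out higher numbers stand for a stronger effect at the one concentration tested and lower numbers for a weaker effect), gives 25.5%;
compound 2, `Cc1cc(O)c(C(C)C)cc1-c1cc(-c2ccccc2Cl)c(C#N)c(=O)[nH]1`, for which compound 2 gives 20%;
compound 3, `COc1cc(-c2cc(-c3cc(C(C)C)c(O)cc3C)[nH]c(=O)c2C#N)ccc1O`, for which compound 3 gives 32%.

Compound 2 and compound 1 cannot be told apart on these numbers, since a number 5.5 percentage points lower from compound 1 to compound 2 (within the scatter). Only compound 3 stands clearly apart from compound 2, as a number 12 percentage points higher from compound 2 to compound 3 (beyond the scatter).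

The next compound is compound 4, `COc1ccc(-c2cc(-c3cc(C(C)C)c(O)cc3C)[nH]c(=O)c2C#N)cc1`. It differs from compound 2 in one place: 4-methoxyphenyl in place of 2-chlorophenyl on an aromatic carbon

Among the compounds with values here, the step that bears most on this change is the one from compound 2 to compound 3, where a 4-hydroxy-3-methoxyphenyl replaced the same 2-chlorophenyl and the number rose by a number 12 percentage points higher from compound 2 to compound 3 (beyond the scatter). Compound 4 carries a 4-methoxyphenyl, which shares the methoxy group but not the hydroxy group of compound 3, so a rise of similar or smaller size is expected, with a step of a number 8 percentage points higher from compound 2 to compound 4 (within the scatter) estimated. Compound 4 is therefore expected to give about 28%, somewhere between 16% and 40%.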

Compound 4, a percentage reported as inhibition, at one concentration (the size of the read-out at that concentration, not a potency): 35%
The estimate for compound 4 lay 7 percentage points below the measured number, within the range that was stated.
By their numbers in this assay, from the lowest: compounds 2, 1, 3 and 4 (each within the scatter of the next, the first and the last beyond it).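

At this position a second group, 4-methoxyphenyl, now stands clearly apart from the 2-chlorophenyl, with a number 15 percentage points higher from compound 2 to compound 4 (beyond the scatter), so the gain seen with compound 3 is not tied to a single replacement. The hydroxy group of compound 3 is not needed to hold that level: the 4-methoxyphenyl carries no hydroxy group, yet the change gives a number 3 percentage points higher from compound 3 to compound 4 (within the scatter). Against the 2-nitrophenyl the same group gives a number 9.5 percentage points higher from compound 1 to compound 4 (within the scatter), so compound 4 cannot be separated from compound 1 on these numbers.

Nothing measured here explains why any of these steps occurs. From the compounds shown here alone, it also remains open whether an amine, a carboxylic acid or a longer chain on the phenyl ring at this position would keep the number at this level.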